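A few compounds are considered here, and "the series" means these few. Any claim that something is new, unique, unknown or untested is made for them only; others in the source may bear on it.

Compound 1, whose structure is `COc1cc(C)cc(-c2c(-c3ccnc(-c4ccc(C(C)=O)cc4)c3)cnn2CC#N)c1`, was tested in a functional assay on MDA-MB-435 cells (Homo sapiens) for inhibition, read by sulforhodamine B assay, with a stated time of 48 h; on this read-out lower numbers stand for higher toxicity in this test and higher numbers for lower toxicity in this test. In this assay compound 1 gives > 100000 nM, which is a limit of the assay rather than a measured number. Two related compounds share that outcome. Compound 2, `COc1cc(C)cc(-c2nn(CC#N)cc2-c2ccc(-c3cccc(C(C)=O)c3)nc2)c1`, likewise reaches only a limit in this assay, at > 100000 nM. Compound 3, `Cc1cc(O)cc(-c2nn(CC#N)cc2-c2ccnc(-c3ccc(N(C)C)cc3)c2)c1`, also stops at a limit in this assay, with > 100000 nM. All three values therefore sit at the same point, described by the limit of > 100000 nM in this assay, at which 3 of the 3 values shown sit, so compound 1 cannot be placed above or below the others; it stands with them at the edge of what the test can report.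

The next compound, compound 4, has the structure `COc1cc(C)cc(-c2c(-c3ccnc(-c4ccc(N(C)C)cc4)c3)cnn2CC#N)c1`. It differs from compound 1 in one place: dimethylamino in place of acetyl on an aromatic carbon. For the measured compounds named here, no step between two measured compounds is available to calibrate this change. Given that compound 1 sits at the limit and that compound 3, which also carries a dimethylamino group, sits at the same limit with > 100000 nM, no shift beyond the scatter is expected in this assay, so the expected step is a step that the limit leaves unreadable from compound 1 to compound 4. For compound 4 the expected result is 150000 nM, between 60000 nM and 400000 nM, most likely again reported only as a limit.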

Compound 4, concentration lethal to 50% of the cells: > 100000 nM
Compound 4: only a limit was reported; the forecaster's own chance of this, stated with the estimate: 85%; the middle value lies beyond the limit too.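

Compound 4 and compound 1 both stop at a limit rather than a number, so no step can be read between them: the limit of > 100000 nM in this assay, at which 4 of the 4 values shown sit.

The compounds shown leave open how dimethylamino and acetyl compare on the shared core, and what change, if any, would give a readable value in this assay.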